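Anilinoquinazoline thioether: from phenyl to 3-chloro-4-fluorophenyl

A few compounds are considered here, and "the series" means these few. Any claim that something is new, unique, unknown or untested is made for them only; others in the source may bear on it.

Three compounds sharing one core have been measured in a functional assay on MCF7 cells (Homo sapiens) for cytotoxicity, read by MTT assay, with a stated time of 72 h; on this read-out lower numbers stand for stronger inhibition and higher numbers for weaker inhibition:
Compound 1, `FC(F)(F)c1ccc(CSc2nc(Nc3ccccc3)c3ccccc3n2)cc1`, gives 44000 nM.
Compound 2, `CCOc1ccccc1Nc1nc(SCc2ccc(C(F)(F)F)cc2)nc2ccccc12`, gives only a limit of the assay, > 50000 nM.
Compound 3, `Cc1ccccc1Nc1nc(SCc2ccc(C(F)(F)F)cc2)nc2ccccc12`, gives 37500 nM.

Compound 1 stands at the higher of the two numbers reported, with compound 3 nearest: the step of a 1.2-fold lower number from compound 1 to compound 3 (0.07 log units; within the scatter) is within the scatter. The step of an at least 1.1-fold higher number from compound 1 to compound 2 (0.05 log units; that floor lies within the scatter) runs to a value that is a limit, the one recorded as the limit of > 50000 nM in this assay, at which 1 of the 3 values shown sits. Within the measured set, a methyl or an ethoxy on the aromatic carbon of the anilino ring therefore moves the read-out by nothing that can be separated from repeat-to-repeat noise.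

Compound 4, `Fc1ccc(Nc2nc(SCc3ccc(C(F)(F)F)cc3)nc3ccccc23)cc1Cl`, is not yet measured. It differs from compound 1 by 3-chloro-4-fluorophenyl in place of phenyl on a nitrogen on an aromatic ring. Going by the values given here, none of the measured steps touches halogen substitution on that ring; the only changes recorded there, methyl and ethoxy, stayed within the scatter. On that basis compound 4 is expected to sit near compound 1, with the expected step of a 1.3-fold lower number from compound 1 to compound 4 (0.10 log units; within the scatter), and a wide range is appropriate. The estimate for compound 4 is 35000 nM, between 12000 nM and 60000 nM.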

Compound 4, half-maximal inhibitory concentration: 23000 nM
The estimate for compound 4 lay 1.5-fold (0.18 log units) above the measured number; low and high end bracket the measured number.
By their numbers in this assay, from the lowest: compounds 4, 3 and 1 (each within the scatter of the next). At a limit, above all of these: compound 2.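

In this assay, going by these compounds alone, the halogenated ring gives the first step at this position that reaches past the scatter, though only against one partner: an at least 2.1-fold lower number from compound 2 to compound 4 (0.33 log units; beyond the scatter). Within the data shown here, the same replacement measured against the unsubstituted ring and the 2-methylphenyl ring gives a 1.9-fold lower number from compound 1 to compound 4 (0.28 log units; within the scatter) and a 1.6-fold lower number from compound 3 to compound 4 (0.21 log units; within the scatter), so 3-chloro-4-fluorophenyl cannot be separated from either phenyl or 2-methylphenyl on this read-out, and the one step beyond the scatter is a floor rather than a measured size. Compound 2 is recorded only as a limit of the assay, so its true distance from compound 4 stays unknown: the limit of > 50000 nM in this assay, at which 1 of the 4 values shown sits.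

The compounds shown leave open whether chlorine or fluorine alone would give a similar read-out, as the two enter here only together, and nothing shown tells what lies behind the step. They also leave open how this position would respond to a group of another kind on the same ring, such as an amine or a carboxylic acid, or to a longer chain in place of the ethoxy of compound 2.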